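Working notes: compound 4 against the measured trio

The compounds below may be only part of what the source reports. "The series", "measured", "known", "first", "only" and "open" are said of these compounds alone.

Measured so far in a functional assay on HeLa cells (Homo sapiens) for cytotoxicity, read by WST assay, with a stated time of 48 h; a lower number here means a stronger inhibitor, a higher number a weaker inhibitor:
Compound 1 `COc1cc(C(c2ccc(O)c(OC)c2)[C@H](C)[C@H](C)CO)ccc1O` gives > 100000 nM; this is a limit of the assay, not a number.
Compound 2 `COC[C@H](C)[C@@H](C)C(c1ccc(O)c(OC)c1)c1ccc(O)c(OC)c1` gives 77000 nM.
Compound 3 `COc1cc(C(c2ccc(O)c(OC)c2)[C@@H](C)[C@H](C)CF)ccc1O` gives 37000 nM.

Compound 2 holds the highest of the two numbers in this assay; its nearest neighbour is compound 3, through the step of a 2.1-fold lower number from compound 2 to compound 3 (0.32 log units; beyond the scatter). Compound 1 sits at the assay limit (the limit of > 100000 nM in this assay, at which 1 of the 3 values shown sits).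

Compound 4 `COc1cc(C(c2ccc(O)c(OC)c2)[C@H](CO)C(C)C)ccc1O` differs from compound 2 in one place: 1-(hydroxymethyl)-2-methylpropyl in place of 2-(methoxymethyl)-1-methylpropyl on a saturated chain carbon bound to two aromatic carbons. The step bearing on it is an at least 1.2-fold lower number from compound 1 to compound 2 (0.11 log units; that floor lies within the scatter), where a methoxymethyl chain replaced a hydroxymethyl chain and the number fell only within the scatter, against a limit. The step of an at least 2.7-fold lower number from compound 1 to compound 3 (0.43 log units; beyond the scatter) shows the fluoromethyl chain lower still. Compound 4 brings back a hydroxymethyl chain, with altered branching, so a move back toward the limit of compound 1 is plausible, probably small or within the scatter.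

Compound 4 is expected in this assay to give 110000 nM, within 45000 nM to 300000 nM. The step this estimate implies is a 1.4-fold higher number from compound 2 to compound 4 (0.15 log units; within the scatter).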

Compound 4, half-maximal inhibitory concentration: > 100000 nM
Compound 4 ended at the assay's limit; the forecaster's own chance of this, stated with the estimate: 50%; the middle value does not contradict the limit.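

With the 1-(hydroxymethyl)-2-methylpropyl chain on the saturated chain carbon bound to two aromatic carbons, compound 4 sits at a limit of this assay, which is not a number: the limit of > 100000 nM in this assay, at which 2 of the 4 values shown sit.

Against the 2-(fluoromethyl)-1-methylpropyl chain, the change gives an at least 2.7-fold higher number from compound 3 to compound 4 (0.43 log units; beyond the scatter), whereas against the 2-(methoxymethyl)-1-methylpropyl chain it gives an at least 1.2-fold higher number from compound 2 to compound 4 (0.11 log units; that floor lies within the scatter), so only the first separation is readable as real. The step from compound 1 to compound 4 cannot be read, so the altered branching shows no measurable change, and both hydroxymethyl-bearing chains remain at the limit.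

Going by these compounds, how far the true values of compound 1 and compound 4 lie past the limit stays open. Also open, on these data alone, is whether an amine, a carboxylic acid or a longer chain at this place would give a number lower than that of compound 3.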